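Shortening the alkylamino chain: compound 3 to compound 4

A few compounds are considered here, and "the series" means these few. Any claim that something is new, unique, unknown or untested is made for them only; others in the source may bear on it.

The series shares one core, carried in compound 1 `CCCCCCCCNc1nccnc1C(=O)NCc1ccccc1`, compound 2 `CCCCCCCCNc1cnc(C(=O)NCc2ccccc2)cn1` and compound 3 `CCCCCCNc1nccnc1C(=O)NCc1ccccc1`. For compound 1 the read-out in an ADME assay on HEL cells (Homo sapiens) for cytotoxicity, read by microscopy, with a stated time of 6 days (on this read-out higher numbers stand for lower toxicity in this test and lower numbers for higher toxicity in this test), is a limit of the assay, > 100000 nM, and not a number. In this assay compound 2 gives 100000 nM and compound 3 gives 100000 nM. Among the compounds with values here, the only single-point step measured so far is a number no higher from compound 1 to compound 3 (the limit leaves the size open), which shows a number no higher but, with one end a limit, leaves its size open. On the numbers shown compound 3 stands level with compound 2 at the digits reported, within the scatter, and the one further value in the set is a limit; the whole set sits at or near (the limit of > 100000 nM in this assay, at which 1 of the 3 values shown sits).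

Compound 4 `CCCCCNc1nccnc1C(=O)NCc1ccccc1` is the next point. It differs from compound 3 by hydrogen in place of methyl on a saturated chain carbon, five bonds along the chain from a nitrogen on an aromatic ring. This is a shortening of the same kind as the measured step, and that step gave no readable size. Within the data shown here, no step seen here moves the read-out beyond the scatter, so for compound 4 the expected change is no change at the digits printed from compound 3 to compound 4 (within the scatter), none beyond the scatter. The estimated value for compound 4 in this assay is 100000 nM, with a range from 50000 nM to 200000 nM.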

Compound 4, minimum cytotoxic concentration: >= 100000 nM
Compound 4 was reported as a limit; the forecaster's own chance of this, stated with the estimate: 40%; the middle value lies on the limit itself.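

Removing the methyl on a saturated chain carbon, five bonds along the chain from a nitrogen on an aromatic ring, gives a number no lower from compound 3 to compound 4 (the limit leaves the size open) in this assay. The earlier shortening pointed only to a number no higher, whereas this one points to a number no lower, and the step from compound 1 to compound 4 cannot be read with a limit at both ends. This change at this position therefore adds no sign of a measurable shift in the read-out, and compound 4 adds a further limit to the set: the limit of >= 100000 nM in this assay, at which 1 of the 4 values shown sits.

Within the data shown here, the size of any effect of chain length in this part of the series stays open, with no step so far carrying a readable size. Also open, going by these compounds, is what a chain ending in an amine or a carboxylic acid would read in this assay, and whether such a group would give a number clearly lower than those of the alkylamino compounds.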